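From trifluoromethyl to hydroxy on compound 2

The source may hold more compounds than are shown below. What is called first, only, known or untested is meant among the compounds shown, and "the series" means these compounds.

Compound 1 `CCCCc1cc(C(=O)OCC)c(NC(=O)c2ccc([N+](=O)[O-])o2)s1`: > 20000 nM (a limit)
Compound 2 `O=C(Nc1ccc(C(F)(F)F)cc1)c1ccc([N+](=O)[O-])o1`: > 20000 nM (a limit)

Both compounds were tested in an ADME assay on HeLa cells (Homo sapiens) for cytotoxicity, read by resazurin assay, with a stated time of 65 h; on this read-out higher numbers stand for an effect only at larger amounts of compound and lower numbers for an effect already at smaller amounts. On these data alone, there, compound 2 gives > 20000 nM, which is a limit and not a number, so its exact standing is unknown. The picture so far is the limit of > 20000 nM in this assay, at which 2 of the 2 values shown sit.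

Compound 3 `O=C(Nc1ccc(O)cc1)c1ccc([N+](=O)[O-])o1` has hydroxy in place of trifluoromethyl on an aromatic carbon, para to a large group: hydroxy in place of trifluoromethyl on an aromatic carbon. Going by the values given here, no measured pair shows what this kind of swap does in this assay, so any forecast is uncertain. The expected step of a number no higher from compound 2 to compound 3 (the limit leaves the size open) is none beyond the usual scatter, in either direction. This expectation rests on compound 2, which gives > 20000 nM, a limit. For compound 3 the expected value is 20000 nM, with an estimated range from 6000 nM to 40000 nM.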

Compound 3, half-maximal effective concentration: > 20000 nM
Compound 3 ended at the assay's limit; the forecaster's own chance of this, stated with the estimate: 70%; the middle value sits exactly at the limit.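

No step can be read from compound 2 to compound 3, because both results in this assay are limits and not numbers: the limit of > 20000 nM in this assay, at which 3 of the 3 values shown sit. The compounds shown leave open where their true values lie, and whether hydroxy in place of trifluoromethyl changes anything here.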